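The compounds below may be only part of what the source reports. "The series", "measured", "known", "first", "only" and "open" are said of these compounds alone.

Of the compounds shown here, two share a core and have been tested in an assay on isolated protein for inhibition of Gonadotropin-releasing hormone receptor (Rattus norvegicus); on this read-out higher numbers stand for weaker inhibition and lower numbers for stronger inhibition. Compound 1 `CCn1c(SCc2cc([N+](=O)[O-])ccc2OC)nc2cc(NC(=O)NC(C)(C)C)ccc21` gives 170 nM, and compound 2 `COCCn1c(SCc2cc([N+](=O)[O-])ccc2OC)nc2cc(NC(=O)NC(C)(C)C)ccc21` gives 280 nM. For the measured compounds named here, the only measured step, a 1.6-fold higher number from compound 1 to compound 2 (0.22 log units; within the scatter), adds a methoxy to the chain on the aromatic nitrogen; of the two numbers the one for compound 2 is the higher, but the gap is within the usual scatter, so the two compounds cannot be told apart in this assay.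

Compound 3 `COc1ccc([N+](=O)[O-])cc1CSc1nc2cc(NC(=O)NC(C)(C)C)ccc2n1Cc1ccccn1` differs from compound 2 by pyridin-2-yl in place of methoxymethyl on a saturated chain carbon bound to an aromatic nitrogen. Going by the values given here, the measured step concerns the same chain, yet it is a smaller change than a pyridin-2-yl ring entering for methoxymethyl, and no measured pair shows a ring at that place. Given that the one change on this chain stayed within the scatter, the expected step of a 1.1-fold lower number from compound 2 to compound 3 (0.05 log units; within the scatter) is small, with wide uncertainty; the estimate for compound 3 is 250 nM, within 80 nM to 800 nM.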

Compound 3, half-maximal inhibitory concentration: 670 nM
Beside the measured number, compound 3's estimate is 2.7-fold (0.43 log units) below it; measured number inside the range.
By their numbers in this assay, from the lowest: compounds 1 and 2 (each within the scatter of the next); then compound 3.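

On this chain on the aromatic nitrogen, the added methoxy had left the number within the scatter, but a ring does not: in this assay pyridin-2-yl in place of methoxymethyl gives a 2.4-fold higher number from compound 2 to compound 3 (0.38 log units; beyond the scatter) and pyridin-2-yl in place of methyl gives a 3.9-fold higher number from compound 1 to compound 3 (0.60 log units; beyond the scatter) as its step. Both steps are beyond the scatter, though modest, so this position is not indifferent to what it carries, and the change weakens inhibition against either earlier compound. No accompanying measurement accounts for this shift.

On these data alone, with a single ring at this place, it remains open whether a plain phenyl ring or a pyridin-4-yl ring would give a similar number. As far as these compounds go, the effect of a longer chain or of a terminal amine on this chain also remains open.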